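Adding a 4-Methylphenyl Group to a Fused Core

The source may hold more compounds than are shown below. What is called first, only, known or untested is meant among the compounds shown, and "the series" means these compounds.

Measured in a functional assay on K562 cells (Homo sapiens) for cytotoxicity, read by MTT assay, with a stated time of 72 h (a higher number here means a weaker inhibitor, a lower number a stronger inhibitor), so far:
compound 1 `COc1ccc(Nc2ccc3ccccc3n2)cc1` gives 30000 nM;
compound 2 `COc1ccc(Nc2cc(-c3ccc(C)cc3)ccn2)cc1` gives 19000 nM;
compound 3 `COc1ccc(Nc2ccccn2)cc1` gives 63000 nM.

Compound 4 `COc1ccc(Nc2nc3ccccc3cc2-c2ccc(C)cc2)cc1` is not yet measured. It differs from compound 1 by 4-methylphenyl in place of hydrogen on an aromatic carbon The same kind of change, 4-methylphenyl in place of hydrogen on an aromatic carbon gave a 3.3-fold lower number from compound 3 to compound 2 (0.52 log units; beyond the scatter). The surroundings differ, though: in compound 4 the new group sits on a fused or bridged system of two rings, ortho to a group of 9 heavy atoms and two atoms from the ring nitrogen, whereas in compound 2 it is meta to that group and opposite the ring nitrogen. The difference between the core of compound 1 and the core of compound 3 is not broken down here. Because the earlier addition gave a 3.3-fold lower number from compound 3 to compound 2 (0.52 log units; beyond the scatter), a step of a 2.3-fold lower number from compound 1 to compound 4 (0.36 log units; beyond the scatter) is expected. Compound 4 is estimated at 13000 nM, likely between 5000 nM and 32000 nM.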

Compound 4, half-maximal inhibitory concentration: 75000 nM
Estimate against measurement, compound 4: 5.8-fold (0.76 log units) below; measured number above the stated range.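

In this assay putting the 4-methylphenyl group in place of hydrogen on the core of compound 1 gives a 2.5-fold higher number from compound 1 to compound 4 (0.40 log units; beyond the scatter) and so runs the opposite way to the earlier step. In this series the change therefore does not carry from one core to the other, even in direction: the same change on two cores in this assay, a 3.3-fold lower number (0.52 log units; beyond the scatter) from compound 3 to compound 2 and a 2.5-fold higher number (0.40 log units; beyond the scatter) from compound 1 to compound 4, 8.3-fold (0.92 log units) apart, beyond the scatter of two such steps

This does not show why, since the cores differ and the new group also sits in a different place on each, and these compounds cannot separate those two differences.

Still open, as far as these compounds go, is whether a methyl group or an amine in the same place on the core of compound 1 would also give a higher number. Also open, from the compounds shown here alone, is what the 4-methylphenyl group would do on another carbon of that core.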